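The compounds below may be only part of what the source reports. "The series", "measured", "known", "first", "only" and "open" are said of these compounds alone.

Working notes on the series.

Going by the values given here, compound 1, `CSc1ccc2c(c1)c(O)c(C(=O)N(C)c1ccccc1)c(=O)n2C`, gives 100% in a functional assay on the whole organism for inhibition, with Mus musculus as the target, at a dose of 32 mg/kg by the oral route (on this read-out lower numbers stand for less inhibition and higher numbers for more inhibition at the one dose given (going by the name of the read-out)), and stands as the highest of the two numbers measured so far. Compound 2, `COCn1c(=O)c(C(=O)N(C)c2ccccc2)c(O)c2cc(SC)ccc21`, gives 78% in this assay. Among the compounds with values here, the only step measured between compounds differing in one place is the one a number 22 percentage points lower from compound 1 to compound 2 (beyond the scatter), which arises from methoxy in place of hydrogen on a saturated chain carbon bound to an aromatic nitrogen.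

Compound 3, `CSc1ccc2c(c1)c(Cl)c(C(=O)N(C)c1ccccc1)c(=O)n2C`, differs from compound 1 by chloro in place of hydroxy on an aromatic carbon. Within the data shown here, no measured step bears on this change: the one step known concerns a different place and a different group, so it gives no guide to the size or direction of the step to compound 3. The hydroxy of compound 1 is removed without any measured counterpart in the series.

Given this, compound 3 is estimated to give 55% in this assay, with a range of 15% to 95%. The step expected from compound 1 to compound 3 is therefore a number 45 percentage points lower from compound 1 to compound 3 (beyond the scatter), carrying wide uncertainty.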

Compound 3, a percentage reported as inhibition, in the whole organism at one dose (the size of the read-out at that dose, not a potency): -1%
Compound 3: the middle estimate sits 56 percentage points above what was measured, outside the stated range (below it).
By their numbers in this assay, from the lowest: compound 3; then compound 2; then compound 1.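

In this assay, chloro in place of hydroxy on an aromatic carbon, opposite the ring nitrogen, gives a number 101 percentage points lower from compound 1 to compound 3 (beyond the scatter) and is the first change shown at this position. This step is much larger than the only earlier one, a number 22 percentage points lower from compound 1 to compound 2 (beyond the scatter), which came from methoxy in place of hydrogen on a saturated chain carbon bound to an aromatic nitrogen. The read-out at the one dose therefore depends strongly on what occupies this aromatic carbon, and in this pair the inhibition seen with hydroxy does not survive its exchange for chloro, although nothing measured on these compounds accounts for the size of the step.

Going by these compounds alone, the single pair cannot separate the loss of hydroxy from the entry of chloro, so an amine or a plain hydrogen at the same aromatic carbon would be needed to show whether other groups keep any of the inhibition. Also open, as far as these compounds go, is whether the same exchange has a comparable effect on the core of compound 2, which carries the methoxy-bearing chain on the aromatic nitrogen.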